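Ethoxycarbonyl in Place of Methyl: An Expected Step

The compounds below may be only part of what the source reports. "The series", "measured", "known", "first", "only" and "open" are said of these compounds alone.

Measured compounds:
- compound 1 `Cc1ccc(NC(=O)N[C@H](C)c2ccccc2)cc1`, 98% in an ADME assay on the whole organism with Oryza sativa as the target, tested at 1 uM; a higher number here means a weaker effect of the compound at the concentration tested, a lower number a stronger effect
- compound 2 `C[C@@H](NC(=O)Nc1ccccc1C(C)(C)C)c1ccccc1`, 95% in this assay
- compound 3 `C[C@@H](NC(=O)Nc1cccc(C(F)(F)F)c1)c1ccccc1`, 72% in this assay

In this assay compound 1 stands highest of the three numbers. Compound 2 lies within the usual scatter of compound 1, so the two cannot be told apart. Compound 3 sits further off, beyond the scatter, with a lower number and thus a stronger effect.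

Compound 4 `CCOC(=O)c1ccc(NC(=O)N[C@H](C)c2ccccc2)cc1` differs from compound 1 by ethoxycarbonyl in place of methyl on an aromatic carbon. Among the compounds with values here, no measured pair here differs in one place, so no step of this kind can be read off. A moderate step downward is expected, roughly at the edge of the scatter. Compound 4 is estimated to give 86%, in a range from 66% to 100%, which means an expected step of a number 12 percentage points lower from compound 1 to compound 4 (beyond the scatter).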

Compound 4, a percentage reported as activity, at one concentration (the size of the read-out at that concentration, not a potency): 100%
The estimate for compound 4 lay 14 percentage points below the measured number; the range from low to high includes it.
By their numbers in this assay, from the lowest: compound 3; then compounds 2, 1 and 4 (each within the scatter of the next).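

Ethoxycarbonyl in place of methyl on this aromatic carbon, para to a large group, gives a number 2 percentage points higher from compound 1 to compound 4 (within the scatter) in this assay. Within the data shown here, this is the first single-place comparison in the set, and it shows that the added heavy atoms and hydrogen-bond acceptors of ethoxycarbonyl leave the read-out indistinguishable from that with methyl. Nothing here shows why the two groups read alike.

As far as these compounds go, whether a carboxylic acid or an amine on this carbon would move the number remains open, as does whether a longer chain would.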